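Chloro substitution read across two related pairs

This account rests on a few compounds, and the source may have more. Where it says the series, first, only, none or still open, it means among the compounds named here.

Two pairs of compounds share a single structural change. Compound 2 `Cc1cc(O)c(C(=O)/C=C/c2ccc(Cl)cc2)c(-c2ccccc2)c1C(=O)/C=C/c1ccc(Cl)cc1` carries a phenyl ring on the shared core, and compound 1 `Cc1cc(O)c(C(=O)/C=C/c2ccc(Cl)cc2)c(-c2ccc(Cl)cc2)c1C(=O)/C=C/c1ccc(Cl)cc1` differs from it by chloro in place of hydrogen on an aromatic carbon. In a functional assay on MDA-MB-231 cells (Homo sapiens) for cytotoxicity, read by MTT assay, with a stated time of 24 h (a lower number here means a stronger inhibitor, a higher number a weaker inhibitor), compound 2 gives 7900 nM, and compound 1 gives 30000 nM; the step of a 3.8-fold higher number from compound 2 to compound 1 (0.58 log units; beyond the scatter) thus moves toward weaker inhibition. Compound 3 `Cc1cc(O)c(C(=O)/C=C/c2cccc3ccccc23)c(-c2ccccc2)c1C(=O)/C=C/c1cccc2ccccc12` belongs to a second core, and the difference between the two cores is not broken down here. In this assay compound 3 is reported as "not active" (no number reported). Compound 4 `Cc1cc(O)c(C(=O)/C=C/c2cccc3ccccc23)c(-c2ccc(Cl)cc2)c1C(=O)/C=C/c1cccc2ccccc12` has not yet been measured and differs from compound 3 by chloro in place of hydrogen on an aromatic carbon, the same change, in the same place, as that between compound 2 and compound 1. Because a 3.8-fold higher number from compound 2 to compound 1 (0.58 log units; beyond the scatter) went toward a higher number, and because compound 3 already gives "not active" (no number reported), no gain is expected for compound 4. Compound 4 is expected to give roughly 100000 nM in this assay, between 30000 nM and 300000 nM, and it is thought likely that no number at all, only an inactive result, will be reported.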

Compound 4, half-maximal inhibitory concentration: 30000 nM
For compound 4 the middle estimate is 3.3-fold (0.52 log units) above the measured one, within the range that was stated.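

In this assay, among the compounds shown here, compound 3 is reported as "not active" (no number reported) and compound 4 gives 30000 nM, so no step from compound 3 to compound 4 can be read. The compounds shown leave open whether phenyl to 4-chlorophenyl moves the number the same way on the core of compound 3 as on the core of compound 2. No measurement offered here bears on this result.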